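This account rests on a few compounds, and the source may have more. Where it says the series, first, only, none or still open, it means among the compounds named here.

Two measured members of the series share one core and differ only in the aryl group on the oxadiazole side. Compound 1 `Oc1ccccc1/C=N/c1nnc(SCc2nnc(-c3ccccc3Cl)o2)s1` gives 18100 nM in a functional assay on MCF7 cells (Homo sapiens) for inhibition, read by CCK-8 assay; a lower number here means a stronger inhibitor, a higher number a weaker inhibitor. Among the measured compounds shown here, compound 2 `COc1ccc(-c2nnc(CSc3nnc(/N=C/c4ccccc4O)s3)o2)cc1` gives 4560 nM in this assay and stands lowest of the two numbers; the one measured step, a 4.0-fold lower number from compound 1 to compound 2 (0.60 log units; beyond the scatter), separates it from compound 1 and lies beyond the scatter. Compound 3 `O=[N+]([O-])c1ccc(-c2nnc(CSc3nnc(/N=C/c4ccccc4O)s3)o2)cc1` is the next candidate. It differs from compound 2 by nitro in place of methoxy on an aromatic carbon. For the measured compounds named here, no measured pair tests this exchange: the single step of a 4.0-fold lower number from compound 1 to compound 2 (0.60 log units; beyond the scatter) swapped a 2-chlorophenyl for a 4-methoxyphenyl and so concerns a different substituent; it shows only that a change on this ring can move the number by a modest amount. Without a closer precedent, the expectation for compound 3 in this assay is a number near that of compound 2, with no step beyond the scatter foreseen in either direction, and a wide range. The step of a 1.3-fold higher number from compound 2 to compound 3 (0.12 log units; within the scatter) is the expected movement. Compound 3 is expected to give 6000 nM, within 1500 nM to 25000 nM.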

Compound 3, half-maximal inhibitory concentration: 4250 nM
Compound 3: middle estimate off by 1.4-fold (0.15 log units), on the high side, within the range that was stated.
By their numbers in this assay, from the lowest: compounds 3 and 2 (each within the scatter of the next); then compound 1.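

In this assay the exchange of methoxy for nitro, para to a large group on the six-membered aromatic ring of carbon only, gives a 1.1-fold lower number from compound 2 to compound 3 (0.03 log units; within the scatter) and so offers a direct reading at this position, where the two groups cannot be told apart despite their different atoms. Compound 1 remains separate from both, since a 4.3-fold lower number from compound 1 to compound 3 (0.63 log units; beyond the scatter) is a step of much the same modest size as a 4.0-fold lower number from compound 1 to compound 2 (0.60 log units; beyond the scatter) and the 2-chlorophenyl compound is the only one of the three on the higher side of the scatter. For these three compounds, then, the 4-methoxyphenyl and 4-nitrophenyl groups read alike, and no measurement at hand bears on why they do.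

Going by these compounds, it remains open whether the gap to compound 1 goes with the chlorine itself or with its place on the ring, a question that a 4-chlorophenyl analogue would address directly. On these data alone, it is also open whether an amine, a carboxylic acid or a longer alkyl chain at the same position would move the number beyond the scatter, or whether this position stays as flat as methoxy and nitro suggest.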